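The compounds below may be only part of what the source reports. "The series", "measured", "known", "first", "only" and "open" are said of these compounds alone.

In a functional assay on MCF7 cells (Homo sapiens) for cytotoxicity, read by MTT assay, with a stated time of 72 h (on this read-out higher numbers stand for weaker inhibition and lower numbers for stronger inhibition), so far:
Compound 1 `N#Cc1ccc(/C=C/C(=O)Nc2cc3c(Nc4ccc(F)c(Cl)c4)ncnc3cc2O[C@H]2CCOC2)cc1` (9830 nM)
Compound 2 `COc1cc(/C=C/C(=O)Nc2cc3c(Nc4ccc(F)c(Cl)c4)ncnc3cc2O[C@H]2CCOC2)cc(OC)c1O` (30500 nM)
Compound 3 `COc1ccc(/C=C/C(=O)Nc2cc3c(Nc4ccc(F)c(Cl)c4)ncnc3cc2O[C@H]2CCOC2)cc1` (5070 nM)

Compound 3 stands clearly apart from one neighbour (a 6.0-fold lower number from compound 2 to compound 3 (0.78 log units; beyond the scatter)) and level with the other (a 1.9-fold lower number from compound 1 to compound 3 (0.29 log units; within the scatter)). Compound 4 `O=C(/C=C/c1ccc(Br)cc1)Nc1cc2c(Nc3ccc(F)c(Cl)c3)ncnc2cc1O[C@H]1CCOC1` differs from compound 3 in one place (bromo in place of methoxy on an aromatic carbon): bromo in place of methoxy on an aromatic carbon, para to a large group. The closest guide is compound 1, where one group is likewise swapped on that carbon (a 1.9-fold lower number from compound 1 to compound 3 (0.29 log units; within the scatter)), and that step stayed within the scatter. Compound 2 differs by more than one group (a 6.0-fold lower number from compound 2 to compound 3 (0.78 log units; beyond the scatter)), so it guides less. A similarly small change is expected here (a 1.3-fold higher number from compound 3 to compound 4 (0.11 log units; within the scatter)), not beyond the scatter. The estimate for compound 4 is 6500 nM, with 2500 nM to 16000 nM as the expected range.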

Compound 4, half-maximal inhibitory concentration: 32400 nM
The estimate for compound 4 lay 5.0-fold (0.70 log units) below the measured number; measured number outside the range, above it.
By their numbers in this assay, from the lowest: compounds 3 and 1 (each within the scatter of the next); then compounds 2 and 4 (each within the scatter of the next).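

At this aromatic carbon, para to a large group, the choice of group now makes a visible difference in this assay. Bromo in place of methoxy gives a 6.4-fold higher number from compound 3 to compound 4 (0.81 log units; beyond the scatter), and bromo in place of cyano gives a 3.3-fold higher number from compound 1 to compound 4 (0.52 log units; beyond the scatter), although methoxy and cyano had stayed level with each other; the 4-bromophenyl compound also sits level with the 4-hydroxy-3,5-dimethoxyphenyl one, at a 1.1-fold higher number from compound 2 to compound 4 (0.03 log units; within the scatter). No measurement available here explains these differences.

Still open, as far as these compounds go, is where an amine, a carboxylic acid or a longer chain on this same carbon would fall in this assay.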